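Series notes: from compound 3 to compound 4

A few compounds are considered here, and "the series" means these few. Any claim that something is new, unique, unknown or untested is made for them only; others in the source may bear on it.

Measured compounds:
- compound 1 `CCOC(=O)C1=C(Nc2ccccc2)S/C(=C\c2ccc(O)c(O)c2)C1=O`: in a functional assay on A549 cells (Homo sapiens) for inhibition, read by MTT assay, with a stated time of 72 h (a higher number here means a weaker inhibitor, a lower number a stronger inhibitor), compound 1 gives > 100000 nM, which is a limit of the assay and not a number.
- compound 2 `CCOC(=O)C1=C(Nc2ccccc2)S/C(=C\c2ccccc2O)C1=O`: in this assay compound 2 gives 16900 nM.
- compound 3 `CCOC(=O)C1=C(Nc2ccccc2)S/C(=C\c2ccc[nH]2)C1=O`: in this assay compound 3 gives > 100000 nM, again a limit of the assay rather than a number.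

Compound 3 therefore stands at the upper edge of what the assay reports, together with compound 1, as the limit of > 100000 nM in this assay, at which 2 of the 3 values shown sit, shows. Within the data shown here, the one readable step into compound 3 is an at least 5.9-fold higher number from compound 2 to compound 3 (0.77 log units; beyond the scatter), a loss; the step of an at least 5.9-fold lower number from compound 1 to compound 2 (0.77 log units; beyond the scatter) is a gain from one limit to a number. The step that the two limits leave unreadable from compound 1 to compound 3 is not readable.

Compound 4 `CCOC(=O)C1=C(Nc2ccccc2)S/C(=C\c2cc3ncccc3[nH]2)C1=O` carries a group of 9 heavy atoms (7 carbon, 2 nitrogen; one five-membered aromatic ring with 1 hetero atom, one six-membered aromatic ring with 1 hetero atom) in place of a group of 5 heavy atoms (4 carbon, 1 nitrogen; one five-membered aromatic ring with 1 hetero atom), on a double-bonded chain carbon bound to a double-bonded ring carbon. Among the measured compounds shown here, no measured step touches this fused group, so nothing measured bears directly on the change. Compound 4 is expected at 50000 nM, within 10000 nM to 150000 nM; this estimated step is an at least 2.0-fold lower number from compound 3 to compound 4 (0.30 log units; that floor lies within the scatter), a cautious gain, with a real chance that only a limit is reported.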

Compound 4, half-maximal inhibitory concentration: 13600 nM
Compound 4: middle estimate off by 3.7-fold (0.57 log units), on the high side, and the stated range covers the measured number.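

In this assay, the change on the double-bonded chain carbon bound to a double-bonded ring carbon turns a limit into a readable number, so 1H-pyrrol-2-yl and the fused group differ clearly: an at least 7.3-fold lower number from compound 3 to compound 4 (0.86 log units; beyond the scatter). The fused group also compares well with the 3,4-dihydroxyphenyl group, an at least 7.3-fold lower number from compound 1 to compound 4 (0.86 log units; beyond the scatter), but not with the 2-hydroxyphenyl group, a 1.2-fold lower number from compound 2 to compound 4 (0.09 log units; within the scatter), so two different aromatic groups at this place now read alike. The values of compound 1 and compound 3 remain limits of the assay, not numbers: the limit of > 100000 nM in this assay, at which 2 of the 4 values shown sit.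

As far as these compounds go, whether the gain needs the nitrogen of the six-membered aromatic ring remains open, and an indol-2-yl group at this place would test that. Also open, from the compounds shown here alone, is how a carboxylic acid in place of the ethyl ester would read with the fused group present.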